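Swapping fluoro for cyano on a well-soluble sulfonamide core

The compounds below may be only part of what the source reports. "The series", "measured", "known", "first", "only" and "open" are said of these compounds alone.

Measured compounds:
Compound 1 `CC(=O)NCc1cccc(Cn2nc(NS(=O)(=O)c3ccc(Cl)s3)c3c(F)cccc32)c1`: >= 139 ug/mL
Compound 2 `CC(=O)NCc1cccc(Cn2nc(NS(=O)(=O)c3ccc(Cl)s3)c3c(O)cccc32)c1`: >= 166 ug/mL

Compound 1 stands at a limit in a physicochemical assay for solubility, read by chemiluminescence, measured as kinetic solubility; on this read-out lower numbers stand for lower solubility and higher numbers for higher solubility: its value of >= 139 ug/mL is a limit of the assay, not a number, as recorded at the limit of >= 139 ug/mL in this assay, at which 1 of the 2 values shown sits. Compound 2 likewise reaches only a limit, >= 166 ug/mL, noted at the limit of >= 166 ug/mL in this assay, at which 1 of the 2 values shown sits. Among the compounds with values here, the one measured step, a step that the two limits leave unreadable from compound 1 to compound 2, therefore cannot be sized, so the shared core is known only to dissolve at or beyond the reach of this assay.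

Compound 3 `CC(=O)NCc1cccc(Cn2nc(NS(=O)(=O)c3ccc(Cl)s3)c3c(C#N)cccc32)c1` differs from compound 1 by cyano in place of fluoro on an aromatic carbon. Within the data shown here, no measured step reads on this change, and the single step that exists is unreadable, so no direction beyond the scatter is expected. The estimate is a step that the limit leaves unreadable from compound 1 to compound 3 for compound 3 from compound 1. Compound 3 is expected to give about 140 ug/mL, within a range from 60 ug/mL to 250 ug/mL, most likely again as a limit.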

Compound 3, solubility: >= 155 ug/mL
Compound 3 gave a limit, no number (the forecaster's own chance of this, stated with the estimate: 60%); at least 1.1-fold (0.04 log units) between middle value and limit.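

Compound 1, compound 2 and compound 3 all stand at limits rather than numbers, so none of the steps among them can be read. The compounds shown leave open how soluble each one really is, and whether fluoro, hydroxy or cyano makes any difference.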